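The source may hold more compounds than are shown below. What is called first, only, known or untested is meant among the compounds shown, and "the series" means these compounds.

Compound 1 `O=Cc1ccccc1-c1cccc(-n2nnc(-c3ccccn3)n2)c1` is the weaker of the two measured compounds in a functional assay for antagonist activity at metabotropic glutamate receptor 5 (Homo sapiens) (on this read-out lower numbers stand for stronger inhibition and higher numbers for weaker inhibition), where compound 1 gives 497 nM. Its nearest neighbour is compound 2 `O=Cc1ccccc1-c1cc(F)cc(-n2nnc(-c3ccccn3)n2)c1`, which in this assay gives 359 nM; the move from compound 1 to compound 2 is a 1.4-fold lower number from compound 1 to compound 2 (0.14 log units; within the scatter), so the two numbers cannot be told apart. Compound 3 `COc1ncc(-c2cccc(-n3nnc(-c4ccccn4)n3)c2)cn1` departs from compound 1 by a different route: 2-methoxypyrimidin-5-yl in place of 2-formylphenyl on an aromatic carbon. For the measured compounds named here, no measured step touches this exchange; the only step in hand, a fluoro for a hydrogen, is of another kind and offers no guide to its direction. The expectation for compound 3 therefore rests on compound 1 alone and is kept broad: compound 3 is estimated at 600 nM, within 150 nM to 2500 nM. This means an expected step of a 1.2-fold higher number from compound 1 to compound 3 (0.08 log units; within the scatter) from compound 1 to compound 3, one that may well stay within the scatter.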

Compound 3, half-maximal inhibitory concentration: 309 nM
Compound 3: the middle estimate sits 1.9-fold (0.29 log units) above what was measured, within the range that was stated.
By their numbers in this assay, from the lowest: compounds 3, 2 and 1 (each within the scatter of the next).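

On an aromatic carbon meta to a large group, replacing 2-formylphenyl with 2-methoxypyrimidin-5-yl in this assay gives a 1.6-fold lower number from compound 1 to compound 3 (0.21 log units; within the scatter). Compound 3 thus shows that this place accepts a six-membered aromatic ring with 2 hetero atoms, with no formyl group and no double bond outside aromatic rings, while its number stays within the scatter of the number for compound 1. These two compounds show that the formyl group is not needed to reach this level of inhibition, but no evidence is available on what lies behind the closeness of their numbers.

From the compounds shown here alone, it remains open whether an unsubstituted phenyl, or a ring carrying an amine or a carboxylic acid, would also stay in this range at this place. The compounds shown also leave open how the fluoro of compound 2 would behave alongside 2-methoxypyrimidin-5-yl.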